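Three thiazole chalcones at the assay limit, a fourth awaited

This account rests on a few compounds, and the source may have more. Where it says the series, first, only, none or still open, it means among the compounds named here.

The study follows three compounds measured in a functional assay on Bel-7402 cells (Homo sapiens) for cytotoxicity, read by MTT assay (a lower number here means a stronger inhibitor, a higher number a weaker inhibitor), and one compound that has not yet been measured. Compound 1 has the structure `COc1cc(/C=C/C(=O)c2sc(Nc3ccc(Cl)cc3)nc2C)cc(OC)c1OC`. Compound 2, `Cc1nc(Nc2ccc(Cl)cc2)sc1C(=O)/C=C/c1ccc(Cl)cc1`, and compound 3, `Cc1nc(Nc2cccc(Cl)c2)sc1C(=O)/C=C/c1ccc(Cl)cc1`, are built on a core that differs from the core of compound 1; the difference between the two cores is not broken down here. Compound 4, `COc1cc(/C=C/C(=O)c2sc(Nc3cccc(Cl)c3)nc2C)cc(OC)c1OC`, is the compound still to be measured.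

In this assay compound 1 gives > 25000 nM, which is a limit of the assay and not a number. Compound 2 gives > 25000 nM, again a limit. Compound 3 gives > 25000 nM, also a limit.

From compound 2 to compound 3 the change is 3-chlorophenyl in place of 4-chlorophenyl on a nitrogen on an aromatic ring. In this assay that step reads a step that the two limits leave unreadable from compound 2 to compound 3, so its size cannot be read from the two limits.

Among the compounds with values here, from compound 1 to compound 4 the change is 3-chlorophenyl in place of 4-chlorophenyl on a nitrogen on an aromatic ring, the same change as the one from compound 2 to compound 3. Within the data shown here, because the size of the earlier step is not readable, the expected step that the limit leaves unreadable from compound 1 to compound 4 rests only on the fact that every value measured so far sits at the limit, described by the limit of > 25000 nM in this assay, at which 3 of the 3 values shown sit. Compound 4 is estimated to give 40000 nM in this assay, in light of the limit of > 25000 nM in this assay, at which 3 of the 3 values shown sit, with a likely range from 20000 nM to 150000 nM.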

Compound 4, half-maximal inhibitory concentration: 14000 nM
Compound 4: the middle estimate sits 2.9-fold (0.46 log units) above what was measured, and the stated range ends above it.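

In this assay, replacing 4-chlorophenyl with 3-chlorophenyl on the core of compound 1 gives an at least 1.7-fold lower number from compound 1 to compound 4 (0.25 log units; that floor lies within the scatter); this is only a floor on the step, so the true size may be larger, but the floor itself lies within the usual scatter and does not on its own establish a real gain. On the other core, compound 3 gives > 25000 nM, which is a limit of the assay and not a number, and the matching step from its 4-chlorophenyl partner, compound 2, cannot be read, as both ends are limits. The series therefore shows a measured value for the 3-chlorophenyl compound on one core only, and it does not show whether the change carries over from one core to the other or has the same size on both, as most of the values give no number to compare: the limit of > 25000 nM in this assay, at which 3 of the 4 values shown sit.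

The compounds shown leave open whether a 3-bromophenyl or a 3-methoxyphenyl on that nitrogen would also give a measurable value on either core. They also leave open whether an amine or a carboxylic acid on that phenyl ring would bring compounds of the other core within the measurable range of this assay.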